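From 2-isopropylphenyl to 3-methoxyphenyl on the shared core

The source may hold more compounds than are shown below. What is called first, only, known or untested is meant among the compounds shown, and "the series" means these compounds.

In an ADME assay on L02 cells (Homo sapiens) for inhibition, read by CCK-8 assay, with a stated time of 48 h (a lower number here means a stronger inhibitor of growth, a higher number a weaker inhibitor of growth), compound 1 `Cc1ccc(CNc2nc(Nc3ccc(N4CCN(C)CC4)cn3)ncc2Cl)cc1` gives > 100000 nM as a limit and not as a number. Compound 2 `COc1ccccc1CNc1nc(Nc2ccc(N3CCN(C)CC3)cn2)ncc1Cl` gives 25500 nM as a measured number. For compound 3 `CC(C)c1ccccc1Nc1nc(Nc2ccc(N3CCN(C)CC3)cn2)ncc1Cl` the entry is "not determined" (no result reported) and so it has no number on this scale. Compared with compound 3, compound 4 `COc1cccc(Nc2nc(Nc3ccc(N4CCN(C)CC4)cn3)ncc2Cl)c1` carries 3-methoxyphenyl in place of 2-isopropylphenyl on a nitrogen on an aromatic ring and is still to be measured. Among the measured compounds shown here, the only measured step is an at least 3.9-fold lower number from compound 1 to compound 2 (0.59 log units; beyond the scatter) and it sits on a saturated chain carbon bound to a nitrogen on an aromatic ring, a different place, so it guides only loosely. With no number for compound 3, no size or direction of step can be expected in this assay from that starting point. The expectation therefore leans on compound 2 at 25500 nM. It also leaves room for a reading at the limit seen for compound 1. Compound 4 is estimated at 30000 nM with an expected range from 8000 nM to 100000 nM for its growth inhibition.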

Compound 4, concentration for 50% growth inhibition: 3470 nM
For compound 4 the middle estimate is 8.6-fold (0.94 log units) above the measured one; the whole stated range lies above it.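

In this assay, among the compounds shown here, the nitrogen on an aromatic ring now carries an aryl group directly, and this gives the first reading without a benzyl group there. Exchanging 2-methoxybenzyl for 3-methoxyphenyl gives a 7.3-fold lower number from compound 2 to compound 4 (0.87 log units; beyond the scatter), and exchanging 4-methylbenzyl for 3-methoxyphenyl gives an at least 28-fold lower number from compound 1 to compound 4 (1.45 log units; beyond the scatter). The second step starts from a limit and not a number, held by compound 1: the limit of > 100000 nM in this assay, at which 1 of the 4 values shown sits.

Compound 3 has no number, and its step to compound 4 cannot be read, so 2-isopropylphenyl and 3-methoxyphenyl remain unranked. The compounds shown do not separate the loss of the benzyl chain carbon from the change of substituent, and they leave open how a carboxylic acid or an amine in place of the methoxy group would read.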